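The compounds below may be only part of what the source reports. "The series", "measured", "known", "first", "only" and "open" are said of these compounds alone.

The three measured compounds share a common core and are compared in an ADME assay on S9 fraction from liver (Mus musculus, strain ICR/CD-1) for metabolic stability, read by LC-MS, using NADPH, with a stated time of 5 min, tested at 2 uM; on this read-out higher numbers stand for a longer-lived compound and lower numbers for a shorter-lived compound. Compound 1 `CC1CCN(C2CCN(S(=O)(=O)c3cccc(-c4ccc(F)cc4)c3)CC2)CC1` gives 1.28 h in this assay and stands second highest among the three numbers. Compound 3 `Cc1c(C)c(S(=O)(=O)N2CCC(N3CCC(C)CC3)CC2)c(C)c2c1OC(C)(C)C2` gives 1.12 h, a number that lies within the usual scatter of that of compound 1. Compound 2 `COc1ccccc1-c1ccc(S(=O)(=O)N2CCC(N3CCC(C)CC3)CC2)cc1` gives 4.82 h, the furthest from compound 1 and beyond the scatter. Within the data shown here, no pair of measured compounds differs in only one place, so no single step can be read from them.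

Compound 4 `Cc1cc(C)cc(-c2cccc(S(=O)(=O)N3CCC(N4CCC(C)CC4)CC3)c2)c1` has not yet been measured in this assay. It differs from compound 1 in one place: 3,5-dimethylphenyl in place of 4-fluorophenyl on an aromatic carbon. Among the measured compounds shown here, no measured pair isolates an exchange of this kind, so the expectation rests on the structural change alone. The step of a 1.6-fold lower number from compound 1 to compound 4 (0.20 log units; within the scatter) is expected to be modest, toward a shorter-lived compound, and may well fall within the scatter. The estimate for compound 4 is 0.8 h, with a range from 0.4 h to 1.7 h.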

Compound 4, half-life: > 4 h
Compound 4 ended at the assay's limit; the forecaster's own chance of this, stated with the estimate: 5%; middle value at least 5.0-fold (0.69 log units) away from the limit.
By their numbers in this assay, from the lowest: compounds 3 and 1 (each within the scatter of the next); then compound 2.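

Among these compounds, at this aromatic carbon, meta to a large group, the exchange of 4-fluorophenyl for 3,5-dimethylphenyl gives the first single step that can be read in this assay: an at least 3.1-fold higher number from compound 1 to compound 4 (0.49 log units; beyond the scatter). The choice of aryl group at this place therefore moves the half-life beyond the scatter, toward a longer-lived compound. For compound 4 the reading is a limit of the assay and not a number, so the full size of the step stays unknown: the limit of > 4 h in this assay, at which 1 of the 4 values shown sits.

Going by these compounds, whether the step comes from the loss of the fluorine or from the gain of the methyl groups stays open, and a plain phenyl group at this place would help to separate the two. On these data alone, how a phenyl ring carrying an amine or a carboxylic acid would fare here is equally open.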